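This account rests on a few compounds, and the source may have more. Where it says the series, first, only, none or still open, it means among the compounds named here.

Measured compounds:
compound 1 `Nc1ncnc2c1ncn2[C@@H]1O[C@@H](CO)C=C1F`: > 100000 nM
compound 2 `Nc1nc(F)nc2c1ncn2[C@@H]1O[C@@H](CO)C=C1F`: > 100000 nM
compound 3 `Nc1nc(F)nc2c1ncn2[C@H]1O[C@@H](CO)C=C1F`: 19500 nM

In a functional assay on CCRF-CEM cells (Homo sapiens) for inhibition (a lower number here means a stronger inhibitor, a higher number a weaker inhibitor), compound 1 gives only a limit, > 100000 nM. Compound 2 likewise gives only a limit, > 100000 nM. Among the measured compounds shown here, compound 3 gives 19500 nM, the only number among the three. Compounds 2 and 3 differ as follows: the two compounds have the same atoms and bonds and differ only in configuration as drawn: 1 of 2 stereo elements differ; a stereocentre at a saturated ring carbon is drawn R in compound 2 and S in compound 3. The step of an at least 5.1-fold lower number from compound 2 to compound 3 (0.70 log units; beyond the scatter) rests on (the fact that compounds 2 and 3 differ only in the configuration as drawn). Compounds 2 and 1 differ by hydrogen in place of fluoro on an aromatic carbon, and the step that the two limits leave unreadable from compound 2 to compound 1 cannot be sized because of the limit of > 100000 nM in this assay, at which 2 of the 3 values shown sit.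

Compound 4 `Nc1ncnc2c1ncn2[C@H]1O[C@@H](CO)C=C1F` has not been measured. It differs from compound 3 by hydrogen in place of fluoro on an aromatic carbon, the same change as from compound 2 to compound 1. Since that earlier step is unreadable, the expectation for compound 4 rests on compound 3 alone: a step of a 2.1-fold higher number from compound 3 to compound 4 (0.31 log units; beyond the scatter) is expected. Compound 4 is therefore estimated at 40000 nM, between 10000 nM and 150000 nM.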

Compound 4, half-maximal inhibitory concentration: > 100000 nM
Compound 4 gave a limit, no number; the forecaster's own chance of this, stated with the estimate: 40%; middle value at least 2.5-fold (0.39 log units) from the limit.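

In this assay, hydrogen in place of fluoro on the core of compound 3 gives an at least 5.1-fold higher number from compound 3 to compound 4 (0.70 log units; beyond the scatter); compound 4 gives only a limit, so this is a lower bound and not a measured size. The same change from compound 2 to compound 1, on the opposite configuration, cannot be read, nor can the step between compound 1 and compound 4, because both ends of each are limits: the limit of > 100000 nM in this assay, at which 3 of the 4 values shown sit. The effect of the change is therefore seen on one configuration only, and nothing shows whether it carries over to the other.

The compounds shown leave open whether chloro or a methyl group in the same place would keep the activity of compound 3.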